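Aryl variation at the chain end: Vero cytotoxicity notes

The compounds below may be only part of what the source reports. "The series", "measured", "known", "first", "only" and "open" are said of these compounds alone.

Values in an ADME assay on Vero cells (Chlorocebus sabaeus) for cytotoxicity, read by MTT assay, with a stated time of 72 h (a lower number here means that less compound is tolerated, a higher number that more compound is tolerated), so far:
compound 1 `O=C(/C=C/c1ccco1)Nc1nnc(-c2ccccc2)[nH]1`: 2180000 nM
compound 2 `Nc1ccc(/C=C/C(=O)Nc2nnc(-c3ccccc3)[nH]2)cc1`: 1910000 nM
compound 3 `O=C(/C=C/c1cccc(Cl)c1)Nc1nnc(-c2ccccc2)[nH]1`: 1470000 nM

Compound 2 stands second highest of the three in this assay. Its nearest neighbour is compound 1, with a 1.1-fold lower number from compound 1 to compound 2 (0.06 log units; within the scatter); its furthest is compound 3, with a 1.3-fold lower number from compound 2 to compound 3 (0.11 log units; within the scatter). Compound 4 `O=C(/C=C/c1ccc(OC(F)(F)F)cc1)Nc1nnc(-c2ccccc2)[nH]1` is obtained from compound 2 by the change (trifluoromethoxy in place of amino on an aromatic carbon). Within the data shown here, the steps that bear on this are the swaps of the group on the double-bonded chain carbon: a 1.1-fold lower number from compound 1 to compound 2 (0.06 log units; within the scatter), a 1.5-fold lower number from compound 1 to compound 3 (0.17 log units; within the scatter) and a 1.3-fold lower number from compound 2 to compound 3 (0.11 log units; within the scatter), all within the scatter. No step beyond the scatter is therefore expected for compound 4, i.e. a 1.1-fold lower number from compound 2 to compound 4 (0.05 log units; within the scatter). Compound 4 is estimated at 1700000 nM, range 750000 nM to 3800000 nM.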

Compound 4, half-maximal cytotoxic concentration: 1560000 nM
Estimate against measurement, compound 4: 1.1-fold (0.04 log units) above; low and high end bracket the measured number.
By their numbers in this assay, from the lowest: compounds 3, 4, 2 and 1 (each within the scatter of the next).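

In this assay the series now has a change on the aromatic carbon itself, with the six-membered ring kept: trifluoromethoxy in place of amino stays within the scatter (a 1.2-fold lower number from compound 2 to compound 4 (0.09 log units; within the scatter)). At this position, then, going from 1 heavy atom to 5 and from 1 hydrogen-bond donor to 0 leaves the number unmoved, as the earlier swaps of the whole group did. Nothing available accounts for this outcome.

Still open, as far as these compounds go, is whether a carboxylic acid or a dimethylamino group on this carbon would give a step beyond the scatter. Also open, from the compounds shown here alone, is how a longer chain between the double bond and the amide would read.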